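Swapping a difluorobenzyl for a phenylethyl on the ring nitrogen

This account rests on a few compounds, and the source may have more. Where it says the series, first, only, none or still open, it means among the compounds named here.

Three compounds share one core and differ only in the group on the amine nitrogen in the ring. Compound 1 `COc1ccc2[nH]c3c(c2c1)CCNC31CCN(Cc2ccccc2Cl)CC1` carries a 2-chlorobenzyl group and gives 2200 nM in an assay on FRT cells for positive allosteric modulation of Cystic fibrosis transmembrane conductance regulator variant N1303K (Homo sapiens), in the presence of a further agent that is not named here; a higher number here means that more compound is needed for the effect, a lower number that less compound is needed. Compound 2 `COc1ccc2[nH]c3c(c2c1)CCNC31CCN(Cc2ccc(F)c(F)c2)CC1` carries a 3,4-difluorobenzyl group and gives 11000 nM. Compound 3 `COc1ccc2[nH]c3c(c2c1)CCNC31CCN(Cc2cccc(F)c2F)CC1` carries a 2,3-difluorobenzyl group and gives 13600 nM, the highest number of the three; its gap to compound 2 lies within the scatter, while a 6.2-fold higher number from compound 1 to compound 3 (0.79 log units; beyond the scatter) and a 5.0-fold higher number from compound 1 to compound 2 (0.70 log units; beyond the scatter) are modest steps beyond it.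

Compound 4 `COc1ccc2[nH]c3c(c2c1)CCNC31CCN(C(C)c2ccccc2)CC1` is not yet measured. Its change is 1-phenylethyl in place of 2,3-difluorobenzyl on an amine nitrogen in a ring. Among the compounds with values here, no measured step removes both fluorines or adds a methyl on the carbon that joins the ring to the nitrogen, so the two modest steps from compound 1 only show that the aryl part can shift the number moderately. The step is therefore expected to be small to modest, likely toward a lower number, as a 2.3-fold lower number from compound 3 to compound 4 (0.36 log units; beyond the scatter). Compound 4 is estimated at 6000 nM, with a range from 1500 nM to 25000 nM.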

Compound 4, half-maximal effective concentration: 20000 nM
For compound 4 the middle estimate is 3.3-fold (0.52 log units) below the measured one; measured number inside the range.
By their numbers in this assay, from the lowest: compound 1; then compounds 2, 3 and 4 (each within the scatter of the next).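

In this assay, 1-phenylethyl on the amine nitrogen in the ring gives a result that cannot be told apart from either difluorobenzyl group, with a 1.5-fold higher number from compound 3 to compound 4 (0.17 log units; within the scatter) and a 1.8-fold higher number from compound 2 to compound 4 (0.26 log units; within the scatter) both lying within the scatter. Removing both fluorines and adding a methyl on the carbon bound to that nitrogen therefore does not bring the number close to that of compound 1, as a 9.1-fold higher number from compound 1 to compound 4 (0.96 log units; beyond the scatter) remains beyond the scatter, so among these four compounds only the 2-chlorobenzyl group stands apart. No supporting data explain this result.

Going by these compounds, because 1-phenylethyl differs from the other groups in more than one way, the separate contributions of the methyl and the aryl substitution remain open. A plain benzyl or 2-methylbenzyl group on this nitrogen would help show whether the chlorine itself matters.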